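The source may hold more compounds than are shown below. What is called first, only, known or untested is meant among the compounds shown, and "the series" means these compounds.

Measured so far in an assay on CHO cells for displacement of a labelled ligand from prostaglandin E2 receptor EP1 subtype (Homo sapiens); on this read-out lower numbers stand for stronger inhibition and higher numbers for weaker inhibition:
- compound 1 `Cc1ccc(S(=O)(=O)N(Cc2nnc(Cc3ccc(N(C)C)cc3)o2)c2cccc(Cl)c2C)cc1`: 12.6 nM
- compound 2 `Cc1ccc(S(=O)(=O)N(Cc2nnc(Cc3ccc(C(F)(F)F)cc3)o2)c2cccc(Cl)c2C)cc1`: 50.1 nM
- compound 3 `Cc1ccc(S(=O)(=O)N(Cc2nnc(Cc3ccc(F)cc3)o2)c2cccc(Cl)c2C)cc1`: 200 nM

Compound 3 stands at the highest number of the three. Its nearest neighbour is compound 2, with a 4.0-fold higher number from compound 2 to compound 3 (0.60 log units; beyond the scatter); the furthest is compound 1, with a 16-fold higher number from compound 1 to compound 3 (1.20 log units; beyond the scatter). The third measured step, a 4.0-fold higher number from compound 1 to compound 2 (0.60 log units; beyond the scatter), runs in the same sense, so in this small set the 4-fluorophenyl carries the weakest binding seen.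

Compound 4 `Cc1ccc(S(=O)(=O)N(Cc2nnc(Cc3ccccc3F)o2)c2cccc(Cl)c2C)cc1` differs from compound 3 as follows: 2-fluorophenyl in place of 4-fluorophenyl on a saturated chain carbon bound to an aromatic carbon. The two have the same atoms, joined differently.

Within the data shown here, none of the measured steps bears on this change directly: each of them exchanges one group for another on the aromatic ring, whereas here the fluorine stays and only its attachment on the ring changes. The measured steps show that the ring substituent matters for this assay, but they give no direction for a rearrangement of this kind. The working expectation is therefore a step in this assay of no change at the digits printed from compound 3 to compound 4 (within the scatter), which is to say no change beyond the scatter, with a wide band around it. For compound 4 the estimated value in this assay is 200 nM, expected to fall between 70 nM and 600 nM.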

Compound 4, half-maximal inhibitory concentration: 501 nM
Estimate against measurement, compound 4: 2.5-fold (0.40 log units) below; low and high end bracket the measured number.
By their numbers in this assay, from the lowest: compound 1; then compound 2; then compound 3; then compound 4.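

In this assay, among these compounds, the attachment of the fluorine on the ring registers by itself, with a 2.5-fold higher number from compound 3 to compound 4 (0.40 log units; beyond the scatter) even though the two compounds have the same atoms; the earlier steps, each exchanging one group for another, could not separate this from a change of group. Replacing 4-(trifluoromethyl)phenyl with 2-fluorophenyl gives a 10-fold higher number from compound 2 to compound 4 (1.00 log units; beyond the scatter) and replacing 4-(dimethylamino)phenyl with it gives a 40-fold higher number from compound 1 to compound 4 (1.60 log units; beyond the scatter), which places compound 4 as the weakest binder of the four and widens the span seen at this position on the saturated chain carbon. No measurement to hand accounts for the effect of moving the fluorine on the ring.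

The compounds shown leave open whether the same move of attachment would shift the number in the same sense and to a similar size with trifluoromethyl or dimethylamino in place of fluoro. Going by these compounds, how other groups on this ring would fall relative to this set also stays open, among them a primary amine, a methoxy group, a carboxylic acid and a longer alkyl chain.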